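The compounds below may be only part of what the source reports. "The series", "measured", "known", "first", "only" and "open" are said of these compounds alone.

Compound 1 `CCN(CC)Cc1ccc2nc(NC(=O)N/N=C/c3cn(Cc4ccccc4Cl)c4ccccc34)sc2c1` gives 900 nM in a functional assay on MDA-MB-231 cells (Homo sapiens) for cytotoxicity, read by MTT assay, with a stated time of 72 h; a lower number here means a stronger inhibitor, a higher number a weaker inhibitor.
Compound 2 `CCN(CC)Cc1ccc2nc(NC(=O)N/N=C/c3c[nH]c4ccccc34)sc2c1` gives 1900 nM in this assay.
Compound 3 `Cc1ccc(Cn2cc(/C=N/NC(=O)Nc3nc4ccc(CN(C)C)cc4s3)c3ccccc32)cc1` gives 1220 nM in this assay.

Compound 2 gives the largest number of the three, though only its gap to compound 1 is beyond the scatter; compound 3 lies within the scatter of compound 2. Compound 4 `CCN(CC)Cc1ccc2nc(NC(=O)N/N=C/c3cn(Cc4cccc(Cl)c4)c4ccccc34)sc2c1` differs from compound 2 by 3-chlorobenzyl in place of hydrogen on an aromatic nitrogen. Among the compounds with values here, one measured step bears on this: a 2.1-fold higher number from compound 1 to compound 2 (0.32 log units; beyond the scatter), the reverse kind of change, a modest step. Running that change the other way, compound 4 is expected to give a modestly lower number than compound 2, a 2.0-fold lower number from compound 2 to compound 4 (0.30 log units; within the scatter). Compound 4 is therefore estimated at 950 nM in this assay, with a likely range from 450 nM to 2000 nM.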

Compound 4, half-maximal inhibitory concentration: 2050 nM
Estimate against measurement, compound 4: 2.2-fold (0.33 log units) below; measured number outside the range, above it.
By their numbers in this assay, from the lowest: compounds 1, 3, 2 and 4 (each within the scatter of the next, the first and the last beyond it).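

In this assay, the 3-chlorobenzyl group on the aromatic nitrogen leaves the number within the scatter of the unsubstituted parent (the step is a 1.1-fold higher number from compound 2 to compound 4 (0.03 log units; within the scatter)), so adding a chlorobenzyl group at this position does not in itself lower the number. Where the chlorine stands on the benzyl group does matter, since 3-chlorophenyl in place of 2-chlorophenyl gives a step beyond the scatter (a 2.3-fold higher number from compound 1 to compound 4 (0.36 log units; beyond the scatter)). Going by these compounds, whether 2-fluorobenzyl or 2-methoxybenzyl at this position would match 2-chlorobenzyl remains open. No evidence here accounts for this difference between the two chlorobenzyl groups.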